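This account rests on a few compounds, and the source may have more. Where it says the series, first, only, none or still open, it means among the compounds named here.

Measured compounds:

Compound 1 `Cc1ccc2c(c1)C1(C(=O)N2Cc2ccccc2)C(C#N)=C(N)Oc2cc3oc(-c4ccccc4)cc(=O)c3c(O)c21`: in a functional assay on NCI-H1299 cells (Homo sapiens) for antiproliferative activity, read by MTT assay, with a stated time of 48 h (a lower number here means a stronger inhibitor, a higher number a weaker inhibitor), compound 1 gives only a limit, > 50000 nM.
Compound 2 `N#CC1=C(N)Oc2cc3oc(-c4ccccc4)cc(=O)c3c(O)c2C12C(=O)N(c1ccccc1)c1ccccc12`: in this assay compound 2 gives only a limit, > 50000 nM.
Compound 3 `CCN1C(=O)C2(C(C#N)=C(N)Oc3cc4oc(-c5ccccc5)cc(=O)c4c(O)c32)c2cccc(C)c21`: in this assay compound 3 gives only a limit, > 50000 nM.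

Where compound 2 stands: its result in this assay is a limit, not a number, and the two other results shown sit at the same limit, so no ordering among the three compounds can be drawn. The whole measured picture is summed up in the limit of > 50000 nM in this assay, at which 3 of the 3 values shown sit.

Compound 4 `N#CC1=C(N)Oc2cc3oc(-c4ccccc4)cc(=O)c3c(O)c2C12C(=O)Nc1ccccc12` is the next entry to be tested. It differs from compound 2 by hydrogen in place of phenyl on an amide-type nitrogen in a ring. Going by the values given here, no pair of measured compounds that differ in one place is available, and no variation at this nitrogen in the three measured compounds has produced a value other than the limit.

Compound 4 is therefore expected to give no result beyond the limit, with an estimate of 60000 nM spanning 20000 nM to 200000 nM. The estimated step from compound 2 to compound 4 is a step that the limit leaves unreadable from compound 2 to compound 4, no change beyond the scatter expected in either direction.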

Compound 4, half-maximal inhibitory concentration: > 50000 nM
Compound 4: a limit, no number; the forecaster's own chance of this, stated with the estimate: 80%; the middle value lies beyond the limit too.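

No step can be read from compound 2 to compound 4: both results in this assay are limits, not numbers. The compounds shown leave open whether any change to the shared core gives a measurable value, as every result sits at one limit: the limit of > 50000 nM in this assay, at which 4 of the 4 values shown sit.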